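Methyl to trifluoromethyl: compound 2 to compound 3

This account rests on a few compounds, and the source may have more. Where it says the series, first, only, none or still open, it means among the compounds named here.

Going by the values given here, in a toxicity assay on MT4 cells (Homo sapiens) for cytotoxicity, read by MTT assay, with a stated time of 5 days (on this read-out lower numbers stand for higher toxicity in this test and higher numbers for lower toxicity in this test), compound 1 `Cc1cc(-c2cccs2)cc(C)c1Nc1ccnc(Nc2ccc(C#N)cc2)n1` gives 10000 nM and compound 2 `Cc1cc(-c2cc(C)c(Nc3ccnc(Nc4ccc(C#N)cc4)n3)c(C)c2)ccn1` gives 4900 nM, the lowest of the two numbers so far. The next structure, compound 3 `Cc1cc(-c2ccnc(C(F)(F)F)c2)cc(C)c1Nc1ccnc(Nc2ccc(C#N)cc2)n1`, carries trifluoromethyl in place of methyl on an aromatic carbon, next to the ring nitrogen: trifluoromethyl in place of methyl on an aromatic carbon. Among the compounds with values here, the only measured step, a 2.0-fold lower number from compound 1 to compound 2 (0.31 log units; beyond the scatter), is modest and comes from a different exchange, so it bears only loosely on this one. Within the data shown here, the expected step is small, a 1.2-fold higher number from compound 2 to compound 3 (0.09 log units; within the scatter), and no measured step fixes its direction. The estimate for compound 3 is 6000 nM, with an expected range of 2500 nM to 15000 nM.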

Compound 3, half-maximal cytotoxic concentration: 6100 nM
The estimate for compound 3 lay 1.0-fold (0.01 log units) below the measured number, within the range that was stated.
By their numbers in this assay, from the lowest: compounds 2, 3 and 1 (each within the scatter of the next, the first and the last beyond it).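

In this assay, trifluoromethyl in place of methyl next to the ring nitrogen gives no readable change (a 1.2-fold higher number from compound 2 to compound 3 (0.10 log units; within the scatter)), so at this position the two groups cannot be told apart in this test. The 2-(trifluoromethyl)pyridin-4-yl group also cannot be told apart from thiophen-2-yl (a 1.6-fold lower number from compound 1 to compound 3 (0.21 log units; within the scatter)), unlike the 2-methylpyridin-4-yl group, whose step from compound 1 lay beyond the scatter. On these data alone, whether an amine or a carboxylic acid at this position would shift the number remains open. No available evidence bears on these results.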